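This account rests on a few compounds, and the source may have more. Where it says the series, first, only, none or still open, it means among the compounds named here.

Four compounds share an amino-thiazole core joined to a bromophenyl group and to a five-membered ring with two nitrogens, and they were tested in a functional assay on RKO cells (Homo sapiens) for cytotoxicity, read by resazurin assay, with a stated time of 72 h; on this read-out higher numbers stand for weaker inhibition and lower numbers for stronger inhibition. Compound 1 `Cc1nccn1-c1csc(Nc2cccc(Br)c2)n1` reaches only a limit of the assay, as in this assay compound 1 gives > 100000 nM. Compound 2 `Brc1ccc(Nc2nc(-n3cnc4ccccc43)cs2)cc1` likewise reaches only a limit, as in this assay compound 2 gives > 100000 nM. How the core of compound 1 and the core of compound 2 differ is not broken down here. Among the measured compounds shown here, compound 3 `Cc1nc2ccccc2n1-c1csc(Nc2ccc(Br)cc2)n1` is the one member with a number rather than a limit: in this assay compound 3 gives 60000 nM. The change from compound 2 to compound 3 is methyl in place of hydrogen on an aromatic carbon, and it made a step of an at least 1.6-fold lower number from compound 2 to compound 3 (0.22 log units; that floor lies within the scatter); that the step carries only a floor follows from the limit of > 100000 nM in this assay, at which 2 of the 3 values shown sit.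

Compound 4 `Cc1cn(-c2csc(Nc3cccc(Br)c3)n2)c(C)n1` has not yet been measured in this assay. It differs from compound 1 by methyl in place of hydrogen on an aromatic carbon. This is the same kind of change as that from compound 2 to compound 3, though not the same: there the methyl entered between two ring nitrogen atoms, next to the ring atom that bears a large group, whereas here it sits next to the ring nitrogen, two ring bonds from the ring nitrogen, two ring bonds from the ring atom that bears a large group, and two ring bonds from the ring atom that bears a methyl group. A step of about an at least 1.1-fold lower number from compound 1 to compound 4 (0.04 log units; that floor lies within the scatter) is expected from compound 1 to compound 4, resting on compound 1 being only a limit at > 100000 nM and on the modest, scatter-sized size of an at least 1.6-fold lower number from compound 2 to compound 3 (0.22 log units; that floor lies within the scatter). Compound 4 is therefore estimated to give about 90000 nM in this assay, with a range from 30000 nM to 300000 nM, and a fair chance that only a limit is reported.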

Compound 4, half-maximal inhibitory concentration: > 100000 nM
Compound 4: only a limit was reported; the forecaster's own chance of this, stated with the estimate: 60%; middle value at least 1.1-fold (0.04 log units) away from the limit.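

Among the compounds shown here, compound 1 and compound 4 both reach only a limit in this assay, so no step between them can be read, because neither has a number to compare: the limit of > 100000 nM in this assay, at which 3 of the 4 values shown sit. The compounds shown leave open whether the added methyl on compound 4 changes the cytotoxicity on these cells at all, and in which direction any such change would go.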